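The source may hold more compounds than are shown below. What is called first, only, known or untested is meant among the compounds shown, and "the series" means these compounds.

Compound 1 `C#CCOc1cccc(/C=C/C(=O)Nc2cc(C(=O)c3cc(OC)c(OC)c(OC)c3)ccc2OC)c1` gives 13400 nM in a functional assay on COLO 205 cells (Homo sapiens) for cytotoxicity, read by MTT assay, with a stated time of 72 h; a lower number here means a stronger inhibitor, a higher number a weaker inhibitor. Compound 2 `COc1cccc(/C=C/C(=O)Nc2cc(C(=O)c3cc(OC)c(OC)c(OC)c3)cc(OC)c2OC)c1` gives 10700 nM in this assay. Compound 3 `COc1ccc(/C=C/C(=O)Nc2cc(C(=O)c3cc(OC)c(OC)c(OC)c3)cc(OC)c2OC)cc1N` gives 10100 nM in this assay.

Compound 3 holds the lowest of the three numbers, yet its gaps to compound 2 and to compound 1 are both within the scatter, so the three compounds read as essentially alike in this assay. Within the data shown here, the single measured one-place step, a 1.1-fold lower number from compound 2 to compound 3 (0.03 log units; within the scatter), swaps the aryl group on the double-bonded chain carbon and leaves the number where it was.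

Compound 4 `C#CCOc1cccc(/C=C/C(=O)Nc2cc(C(=O)c3cc(OC)c(OC)c(OC)c3)cc(OC)c2OC)c1` has not yet been measured. It differs from compound 3 in that (3-(propargyloxy)phenyl in place of 3-amino-4-methoxyphenyl on a double-bonded chain carbon bound to a double-bonded chain carbon). Among the measured compounds shown here, the step from compound 2 to compound 3 is the only measured change of the same kind, at the same place, and it was small. The entering group is also present in compound 1, whose core lacks one methoxy group compared with compound 4; the values of compound 1 and compound 3 lie within the scatter of each other. The expected step is therefore a 1.1-fold higher number from compound 3 to compound 4 (0.06 log units; within the scatter), no movement beyond the scatter. Compound 4 is estimated at 11500 nM, with a range from 6000 nM to 22000 nM.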

Compound 4, half-maximal inhibitory concentration: 11200 nM
Beside the measured number, compound 4's estimate is 1.0-fold (0.01 log units) above it; the measured number falls inside the stated range.
By their numbers in this assay, from the lowest: compounds 3, 2, 4 and 1 (each within the scatter of the next).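

Putting 3-(propargyloxy)phenyl in place of 3-amino-4-methoxyphenyl on a double-bonded chain carbon bound to a double-bonded chain carbon gives a 1.1-fold higher number from compound 3 to compound 4 (0.04 log units; within the scatter) in this assay, so a second swap at this place, which removes the nitrogen and brings in a triple bond, also leaves the number where it was. Two further one-place comparisons read the same way: ethynyl in place of hydrogen on a saturated chain carbon bound to an oxygen on an aromatic ring gives a 1.0-fold higher number from compound 2 to compound 4 (0.02 log units; within the scatter), and methoxy in place of hydrogen on an aromatic carbon gives a 1.2-fold lower number from compound 1 to compound 4 (0.08 log units; within the scatter), so neither change moves the number beyond the scatter in these pairs. Nothing measured here offers a reason for this flat picture.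

All four compounds sit so close together that none of the changes shown marks out a group that moves the number at all. As far as these compounds go, whether a carboxylic acid or a longer chain at the same place, or a saturated chain in place of the double-bonded chain carbons, would shift it remains open.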